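Trading the Thiazolidinedione for a Triazole

The source may report more compounds than this note shows. Statements on the series, on what has been measured and on what is new or still open speak of the compounds shown alone.

Of the compounds shown here, three built on a shared core have been measured in a physicochemical assay for lipophilicity, read by HPLC, measured as octanol-water partition; on this read-out lower numbers stand for lower lipophilicity and higher numbers for higher lipophilicity. Compound 1 `COC(=O)CC1CCN(C[C@H]2CN(c3ccc(-n4cc(-c5ccccn5)cn4)c(F)c3)C(=O)O2)CC1` gives 1.78. Compound 2 `O=C1O[C@@H](CN2CCC(O)CC2)CN1c1ccc(-n2cc(-c3ccccn3)cn2)c(F)c1` gives 1.63. Compound 3 `O=C1CSC(=O)N1C[C@H]1CN(c2ccc(-n3cc(-c4ccccn4)cn3)c(F)c2)C(=O)O1` gives 2.18, the highest of the three numbers; compound 1 stands nearest to it, beyond the scatter, and compound 2 furthest.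

Compound 4 `O=C1O[C@@H](Cn2ccnn2)CN1c1ccc(-n2cc(-c3ccccn3)cn2)c(F)c1` awaits measurement in this assay. It differs from compound 3 in a single place: 1H-1,2,3-triazol-1-yl in place of 2,4-dioxo-1,3-thiazolidin-3-yl on a saturated chain carbon bound to a saturated ring carbon. Going by the values given here, two measured steps bear on this position, since both end at compound 3 and change the same carbon. In this assay there was a number 0.40 log units higher from compound 1 to compound 3 (beyond the scatter) and a number 0.55 log units higher from compound 2 to compound 3 (beyond the scatter); in each case the arrival of the thiazolidinedione raised the number by a modest, detectable amount. Compound 4 removes that same group again, and what enters is a smaller aromatic ring with the same number of acceptors and no sulfur or carbonyl oxygens. Compound 4 is therefore expected to return toward the level of compound 1 and compound 2, giving an estimated 1.7, with a range from 1.3 to 2.1. This estimate means an expected step of a number 0.48 log units lower from compound 3 to compound 4 (beyond the scatter), downward and somewhat beyond the scatter.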

Compound 4, partition coefficient: 2
Beside the measured number, compound 4's estimate is 0.30 log units below it; the range from low to high includes it.
By their numbers in this assay, from the lowest: compounds 2, 1, 4 and 3 (each within the scatter of the next, the first and the last beyond it).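

In this assay, the first aromatic ring seen on this saturated chain carbon, 1H-1,2,3-triazol-1-yl with 5 heavy atoms, replaces the 7 heavy atoms of 2,4-dioxo-1,3-thiazolidin-3-yl and gives a number 0.18 log units lower from compound 3 to compound 4 (within the scatter), so this exchange cannot be told apart from repeated measurement. Going by these compounds alone, the same ring in place of the two piperidine groups reads differently: it gives a number 0.37 log units higher from compound 2 to compound 4 (beyond the scatter) against 4-hydroxypiperidin-1-yl but a number 0.22 log units higher from compound 1 to compound 4 (within the scatter) against 4-((methoxycarbonyl)methyl)piperidin-1-yl, so compound 4 stands clearly apart only from compound 2, whereas the earlier compounds had placed compound 3 beyond the scatter from both piperidine compounds. Nothing available here explains these differences.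

On these data alone, what remains open is whether the ring's aromatic character or its nitrogen atoms set the number at this position, which a comparison of 1H-1,2,3-triazol-1-yl with its isomer 2H-1,2,3-triazol-2-yl, or with a plain 1H-imidazol-1-yl ring, could begin to separate. It also remains open how far the number would move with a carboxylic acid or a primary amine on this saturated chain carbon, since every group shown carries no net charge.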